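Aryl variation on a shared core: antiproliferative read-out

The source may hold more compounds than are shown below. What is called first, only, known or untested is meant among the compounds shown, and "the series" means these compounds.

Measured compounds:
- compound 1 `O=C1O/C(=C\Cn2cc(-c3ccc(Br)cc3)nn2)C(OCc2ccccc2)=C1OCc1ccccc1`: in a functional assay on HepG2 cells (Homo sapiens) for antiproliferative activity, read by MTT assay, with a stated time of 72 h (on this read-out lower numbers stand for stronger inhibition and higher numbers for weaker inhibition), compound 1 gives only the assay limit > 100000 nM.
- compound 2 `Cc1ccc(-c2cn(C/C=C3\OC(=O)C(OCc4ccccc4)=C3OCc3ccccc3)nn2)cc1`: in this assay compound 2 gives only the assay limit > 100000 nM.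
- compound 3 `O=C1O/C(=C\Cn2cc(-c3cc(F)cc(F)c3)nn2)C(OCc2ccccc2)=C1OCc1ccccc1`: in this assay compound 3 gives only the assay limit > 100000 nM.

Compound 3 thus stands at the limit, not at a number, together with the two other values; all three sit at the limit of > 100000 nM in this assay, at which 3 of the 3 values shown sit. No ordering among compound 1, compound 2 and compound 3 can be read from this.

The next compound is compound 4 `CCCCCc1ccc(-c2cn(C/C=C3\OC(=O)C(OCc4ccccc4)=C3OCc3ccccc3)nn2)cc1`, which differs from compound 3 by 4-pentylphenyl in place of 3,5-difluorophenyl on an aromatic carbon. The measured steps that touch this position, a step that the two limits leave unreadable from compound 1 to compound 3, a step that the two limits leave unreadable from compound 2 to compound 3 and a step that the two limits leave unreadable from compound 1 to compound 2, are all unreadable in size, since each end is a limit. None of them shows that changing the aryl group moves this series into the measurable range, and none rules it out.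

In this assay compound 4 is therefore expected to remain weak, with an estimate of 90000 nM, spanning 20000 nM to 300000 nM, and the expected step is an at least 1.1-fold lower number from compound 3 to compound 4 (0.04 log units; that floor lies within the scatter); a reported limit rather than a number is the most likely outcome.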

Compound 4, half-maximal inhibitory concentration: > 100000 nM
Compound 4 was reported as a limit; the forecaster's own chance of this, stated with the estimate: 70%; middle value at least 1.1-fold (0.04 log units) from the limit.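

In this assay compound 4 gives > 100000 nM, a limit and not a number. Its steps to compound 1, compound 2 and compound 3 therefore cannot be read in size. The compounds shown leave open whether any aryl group on the shared core gives a measurable value, as all remain at the limit: the limit of > 100000 nM in this assay, at which 4 of the 4 values shown sit.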